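The source may hold more compounds than are shown below. What is called first, only, known or untested is meant among the compounds shown, and "the series" means these compounds.

Compound 1 `O=C1C(Nc2cccc(F)c2)=CC(=O)c2ncccc21` and compound 2 `O=C1C(Nc2cc(F)cc(F)c2)=CC(=O)c2ncccc21` share one core, while compound 3 `O=C1C=C(Nc2ccc(F)cc2)C(=O)c2cnccc21` and compound 4 `O=C1C=C(Nc2ccc(F)cc2F)C(=O)c2cnccc21` share another. In a functional assay on the whole organism (aorta) with Rattus norvegicus as the target (a higher number here means a larger maximal response, a lower number a smaller maximal response), compound 1 gives 85% and compound 2 gives 91%; the change between them is fluoro in place of hydrogen on an aromatic carbon, and the step it made is a number 6 percentage points higher from compound 1 to compound 2 (within the scatter). The difference between the two cores is not broken down here. In this assay compound 3 gives 72%, the lowest of the three measured values. Compound 4 has not yet been measured; it differs from compound 3 by fluoro in place of hydrogen on an aromatic carbon, the same kind of change as before, though here the entering group sits ortho to a large group rather than meta to it. Because the earlier step was a number 6 percentage points higher from compound 1 to compound 2 (within the scatter), a similarly small step is expected here, about a number 4 percentage points higher from compound 3 to compound 4 (within the scatter). Compound 4 is therefore estimated at 76%, between 60% and 92%.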

Compound 4, largest response reached (Emax), in percent of the reference or control that the assay uses: 96%
Estimate against measurement, compound 4: 20 percentage points below, and the stated range ends below it.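

In this assay, fluoro in place of hydrogen on an aromatic carbon gives a number 24 percentage points higher from compound 3 to compound 4 (beyond the scatter). Set beside the earlier step, the size of this change does not carry over unchanged from one core to the other: the same change on two cores in this assay, a number 6 percentage points higher (within the scatter) from compound 1 to compound 2 and a number 24 percentage points higher (beyond the scatter) from compound 3 to compound 4, 18 percentage points apart, beyond the scatter of two such steps These two pairs do not show that the core sets the size of the step, for the entering fluoro group in compound 4 also sits ortho to a large group, and the two differences cannot be told apart here.

The compounds shown leave open how a fluoro group ortho to the large group would act on the core of compound 1. They also leave open whether a chloro or methoxy group entering in place of that hydrogen would give a similar step.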